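Phenyl in Place of Methoxy: What to Expect for Compound 4

The source may report more compounds than this note shows. Statements on the series, on what has been measured and on what is new or still open speak of the compounds shown alone.

Three compounds share one core. Compound 1 `CCCCCCCCc1c(-c2ccccc2)sc(C(C)C)c1/C=C/[C@@H](O)C[C@@H](O)CC(=O)O` carries an octyl group on an aromatic carbon; in an assay on microsomes for inhibition of 3-hydroxy-3-methylglutaryl-coenzyme A reductase (Rattus norvegicus) (a lower number here means a stronger inhibitor, a higher number a weaker inhibitor), compound 1 gives only a limit, > 10000 nM (the limit of > 10000 nM in this assay, at which 1 of the 3 values shown sits). Compound 2 `CC(C)c1sc(-c2ccccc2)c(-c2cccc(C(F)(F)F)c2)c1/C=C/[C@@H](O)C[C@@H](O)CC(=O)O` bears a 3-(trifluoromethyl)phenyl group there and gives 2980 nM. Compound 3 `COc1ccc(-c2c(-c3ccccc3)sc(C(C)C)c2/C=C/[C@@H](O)C[C@@H](O)CC(=O)O)cc1` bears a 4-methoxyphenyl group and gives 2430 nM, the lowest of the two numbers shown. The steps are an at least 3.3-fold lower number from compound 1 to compound 2 (0.52 log units; beyond the scatter) and an at least 4.1-fold lower number from compound 1 to compound 3 (0.61 log units; beyond the scatter), while a 1.2-fold lower number from compound 2 to compound 3 (0.09 log units; within the scatter).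

Compound 4 `CC(C)c1sc(-c2ccccc2)c(-c2ccc(-c3ccccc3)cc2)c1/C=C/[C@@H](O)C[C@@H](O)CC(=O)O` differs from compound 3 in one place: phenyl in place of methoxy on an aromatic carbon. Among the compounds with values here, no measured step exchanges one group for another on that ring, so the only bearing evidence is the comparison of compound 2 with compound 3, where two different aromatic rings on the core give numbers within the scatter of each other. A step from compound 3 to compound 4 of no more than the scatter is therefore expected, a 1.1-fold lower number from compound 3 to compound 4 (0.04 log units; within the scatter). Compound 4 is estimated at 2200 nM, within 600 nM to 8000 nM.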

Compound 4, half-maximal inhibitory concentration: > 10000 nM
Compound 4: a limit, no number (the forecaster's own chance of this, stated with the estimate: 10%); at least 4.5-fold (0.65 log units) between middle value and limit.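

Phenyl in place of methoxy on an aromatic carbon, para to a large group, brings an at least 4.1-fold higher number from compound 3 to compound 4 (0.61 log units; beyond the scatter) in this assay, and 4-phenylphenyl in place of 3-(trifluoromethyl)phenyl brings an at least 3.3-fold higher number from compound 2 to compound 4 (0.52 log units; beyond the scatter) as well. The earlier compounds shown here gave no sign of this, as the numbers of compound 2 and compound 3, with their two different aromatic rings, lay within the scatter of each other; the group carried at this place can therefore matter. Compound 4 and compound 1 both give only a limit, and the step between them cannot be read: the limit of > 10000 nM in this assay, at which 2 of the 4 values shown sit.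

Going by these compounds, it remains open whether a chlorine, a methyl or a hydroxyl group on that same carbon would keep the number close to that of compound 3. On these data alone, how far the true number of compound 4 lies past its limit also remains unknown.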